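A few compounds are considered here, and "the series" means these few. Any claim that something is new, unique, unknown or untested is made for them only; others in the source may bear on it.

Measured so far:
compound 1, `CCCn1c(=O)[nH]c2nc(-c3ccc(S(=O)(=O)N4CCN(c5ccc(Cl)cc5F)CC4)cc3)[nH]c2c1=O` — 9%
compound 2, `CCCn1c(=O)[nH]c2nc(-c3ccc(S(=O)(=O)N4CCN(c5ccc(Br)cc5)CC4)cc3)[nH]c2c1=O` — 13%
compound 3, `CCCn1c(=O)[nH]c2nc(-c3ccc(S(=O)(=O)N4CCN(c5cccc(F)c5)CC4)cc3)[nH]c2c1=O` — 34%

In an assay on CHO cells for displacement of a labelled ligand from adenosine receptor A1 (Homo sapiens), read by scintillation counting, with a stated time of 90 min, tested at 1 uM, in the presence of a further agent that is not named here (a lower number here means less inhibition, a higher number more inhibition at the concentration tested (going by the name of the read-out)), compound 1 gives 9%, the lowest of the three numbers. Compound 2, which differs only in the aryl group on the ring amine, gives 13%, a change of a number 4 percentage points higher from compound 1 to compound 2 (within the scatter). Compound 3 gives 34%, a change of a number 25 percentage points higher from compound 1 to compound 3 (beyond the scatter), and against compound 2 the change is a number 21 percentage points higher from compound 2 to compound 3 (beyond the scatter).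

Compound 4, `CCCn1c(=O)[nH]c2nc(-c3ccc(S(=O)(=O)N4CCN(c5ccccc5Cl)CC4)cc3)[nH]c2c1=O`, is the next variation on the same core, with 2-chlorophenyl in place of 4-chloro-2-fluorophenyl on an amine nitrogen in a ring. Two of the measured steps bear on it. The step of a number 4 percentage points higher from compound 1 to compound 2 (within the scatter) shows that swapping the halogens on this aryl group while keeping it otherwise plain barely moves the number. For the measured compounds named here, the steps of a number 25 percentage points higher from compound 1 to compound 3 (beyond the scatter) and a number 21 percentage points higher from compound 2 to compound 3 (beyond the scatter) show a modest gain, but only when the 3-fluorophenyl enters, and none of the measured compounds carries a 2-chlorophenyl. The expectation for compound 4 is therefore a step of a number 6 percentage points higher from compound 1 to compound 4 (within the scatter), likely within the scatter. Compound 4 is estimated to give 15% in this assay, with a range from 3% to 35%.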

Compound 4, a percentage reported as inhibition, at one concentration (the size of the read-out at that concentration, not a potency): 25%
Compound 4: the middle estimate sits 10 percentage points below what was measured; low and high end bracket the measured number.
By their numbers in this assay, from the lowest: compounds 1 and 2 (each within the scatter of the next); then compounds 4 and 3 (each within the scatter of the next).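

In this assay the change to 2-chlorophenyl gives a number 16 percentage points higher from compound 1 to compound 4 (beyond the scatter) and also a number 12 percentage points higher from compound 2 to compound 4 (beyond the scatter), so a gain at this position on the ring amine is no longer tied to 3-fluorophenyl alone. Against 3-fluorophenyl, the step is a number 9 percentage points lower from compound 3 to compound 4 (within the scatter), so this assay cannot separate those two groups, and both stand clear of 4-chloro-2-fluorophenyl and 4-bromophenyl. Nothing measured here explains why these aryl groups differ.

The compounds shown leave open how a plain phenyl, a 3-chlorophenyl or a 2-methoxyphenyl group would read here, and such groups would help show whether the kind of substituent or its place on the aryl ring matters more, since the groups shown change both at once. As far as these compounds go, the read-out also gives the size of the inhibition at a single concentration, so it remains open how compound 3 and compound 4 would compare in potency across a range of concentrations.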